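This account rests on a few compounds, and the source may have more. Where it says the series, first, only, none or still open, it means among the compounds named here.

Of the compounds shown here, three built on one shared core have so far been tested in a functional assay on PANC-1 cells (Homo sapiens) for inhibition, read by MTT assay, with a stated time of 24 h, tested at 10 uM; on this read-out higher numbers stand for more inhibition at the one concentration tested (going by the name of the read-out) and lower numbers for less inhibition. Compound 1 `CC(C)=CCC/C(C)=C/CC1Cc2c(OCCCNS(=O)(=O)c3ccc(Cl)cc3)cc(=O)n(CCCO)c2CC1(C)C` gives 14.5% in this assay. Compound 2 `CC(C)=CCC/C(C)=C/CC1Cc2c(OCCCNS(=O)(=O)c3ccc(Br)cc3)cc(=O)n(CCCO)c2CC1(C)C` gives 15.2%. Compound 3 `CC(C)=CCC/C(C)=C/CC1Cc2c(OCCCNC(=O)c3ccco3)cc(=O)n(CCCO)c2CC1(C)C` gives 69.5%, the highest of the three numbers: the steps of a number 55 percentage points higher from compound 1 to compound 3 (beyond the scatter) and a number 54.3 percentage points higher from compound 2 to compound 3 (beyond the scatter) are both large, whereas a number 0.7 percentage points higher from compound 1 to compound 2 (within the scatter) lies within the scatter.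

Compound 4 `CC(C)=CCC/C(C)=C/CC1Cc2c(OCCCNC(=O)c3ccc([N+](=O)[O-])cc3)cc(=O)n(CCCO)c2CC1(C)C` is not yet measured. It differs from compound 3 in one place: 4-nitrophenyl in place of furan-2-yl on a carbonyl carbon. The carbonyl amide that sets compound 3 apart from compounds 1 and 2 is kept; only the ring on the carbonyl carbon is exchanged. Within the data shown here, no measured step touches that ring, so the two large steps into compound 3 show only that the amide-bearing compound read high, not how a different aromatic ring on that carbonyl would read. Among the measured compounds shown here, the one step that swaps substituents on an aromatic ring was within the scatter, but it concerns the sulfonyl compounds, not the amide.

The expectation for compound 4 is therefore a step of a number 19.5 percentage points lower from compound 3 to compound 4 (beyond the scatter) in this assay, with wide uncertainty in both directions. Compound 4 is estimated at 50%, between 25% and 75%.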

Compound 4, a percentage reported as inhibition, at one concentration (the size of the read-out at that concentration, not a potency): 16.8%
Estimate against measurement, compound 4: 33.2 percentage points above, outside the stated range (below it).
By their numbers in this assay, from the lowest: compounds 1, 2 and 4 (each within the scatter of the next); then compound 3.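

In this assay, the ring on the carbonyl carbon matters a great deal: with the amide kept, 4-nitrophenyl in place of furan-2-yl gives a number 52.7 percentage points lower from compound 3 to compound 4 (beyond the scatter), so the carbonyl amide by itself does not secure the high reading of compound 3. Set against the sulfonyl compounds, the steps of a number 1.6 percentage points higher from compound 2 to compound 4 (within the scatter) and a number 2.3 percentage points higher from compound 1 to compound 4 (within the scatter) show that this amide reads alike to them, which leaves compound 3, with its furan-2-yl, as the only one of the four that stands apart. Nothing measured here explains why this ring exchange has so large an effect.

The compounds shown leave open which part of the exchange counts, since a five-membered ring with its oxygen leaves and a six-membered carbon ring bearing a nitro group enters in a single step. A plain phenyl on the carbonyl would separate the ring from the nitro group, while a thiophene in place of the furan would test whether the ring oxygen is needed.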